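Hydroxyl to Carboxamide on the Cyclohexyl Ring

The source may report more compounds than this note shows. Statements on the series, on what has been measured and on what is new or still open speak of the compounds shown alone.

Measured compounds:
compound 1, `N#Cc1cnc(NCc2ccccc2C(F)(F)F)cc1N[C@H]1CC[C@H](O)CC1`, 4000 nM;
compound 2, `CO[C@H]1CC[C@H](Nc2cc(NCc3cnccc3C(F)(F)F)ncc2C#N)CC1`, 1100 nM;
compound 3, `N#Cc1cnc(NCc2cnccc2C(F)(F)F)cc1NCC1CCOCC1`, 400 nM.

In an assay on isolated protein for inhibition of protein kinase C theta type (Homo sapiens), read by TR-FRET, with a stated time of 2 h (a higher number here means a weaker inhibitor, a lower number a stronger inhibitor), compound 1 gives the highest of the three numbers; compound 2 lies closer to it and compound 3 furthest away. Going by the values given here, the one step measured within a single change, a 2.8-fold lower number from compound 2 to compound 3 (0.44 log units; beyond the scatter), concerns a different part of the shared core and does not bear on the change studied here. Compound 4, `N#Cc1cnc(NCc2ccccc2C(F)(F)F)cc1N[C@H]1CC[C@@H](C(N)=O)CC1`, differs from compound 1 by 4-carbamoylcyclohexyl in place of 4-hydroxycyclohexyl on a nitrogen on an aromatic ring. Among the compounds with values here, no measured pair tests this change, so the expectation for compound 4 rests on compound 1 alone, with a small step in either direction possible. The expected step of a 1.6-fold lower number from compound 1 to compound 4 (0.20 log units; within the scatter) is modest. Compound 4 is estimated at 2500 nM, within 800 nM to 8000 nM.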

Compound 4, half-maximal inhibitory concentration: 20 nM
Compound 4: the middle estimate sits 130-fold (2.10 log units) above what was measured, and the stated range ends above it.
By their numbers in this assay, from the lowest: compound 4; then compound 3; then compound 2; then compound 1.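

In this assay the step of a 200-fold lower number from compound 1 to compound 4 (2.30 log units; beyond the scatter) shows that the group on this nitrogen can strongly change the number: with the rest of compound 1 kept, 4-carbamoylcyclohexyl in place of 4-hydroxycyclohexyl moves it far beyond the scatter. No available evidence accounts for a step of this size.

On these data alone, whether a carboxylic acid or an amine at the same place on the cyclohexyl ring would give a similar step remains open. So does whether the 4-carbamoylcyclohexyl group would have the same effect on the core of compound 2.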